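The source may report more compounds than this note shows. Statements on the series, on what has been measured and on what is new or still open speak of the compounds shown alone.

Measured so far in a functional assay on MCF7 cells (Homo sapiens) for cytotoxicity, read by MTT assay, with a stated time of 72 h; a lower number here means a stronger inhibitor, a higher number a weaker inhibitor:
Compound 1 `COc1cccc(/C=C2\CCC/C(=C\c3ccc(O)cc3)C2=O)c1OC` gives > 20000 nM, which is a limit of the assay and not a number.
Compound 2 `COc1cccc(/C=C2\CCC/C(=C\c3cccc(Cl)c3Cl)C2=O)c1OC` gives > 20000 nM, likewise a limit of the assay.
Within the data shown here, compound 3 `COc1ccc(/C=C2\CCC/C(=C\c3ccc(O)cc3)C2=O)cc1OC` gives 17000 nM, the only number in the set.

Compound 1 and compound 3 are built from the same atoms joined differently; the difference between the two cores is not broken down here. From compound 1 to compound 2 the change is 2,3-dichlorophenyl in place of 4-hydroxyphenyl on a double-bonded chain carbon bound to a double-bonded ring carbon. The resulting step, a step that the two limits leave unreadable from compound 1 to compound 2, cannot be read because the limit of > 20000 nM in this assay, at which 2 of the 3 values shown sit, covers both ends of it. Compound 4 `COc1ccc(/C=C2\CCC/C(=C\c3cccc(Cl)c3Cl)C2=O)cc1OC` is not yet measured; it differs from compound 3 by 2,3-dichlorophenyl in place of 4-hydroxyphenyl on a double-bonded chain carbon bound to a double-bonded ring carbon, the same change at the same place. Compound 3, with 17000 nM, already sits near the top of the range that the assay reports as a number. Compound 4 is therefore expected to show a step of a 1.5-fold higher number from compound 3 to compound 4 (0.17 log units; within the scatter), a size guessed rather than read, since the earlier step gives no number. On this basis compound 4 is estimated at 25000 nM, most likely returned as a limit.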

Compound 4, half-maximal inhibitory concentration: 14300 nM
Beside the measured number, compound 4's estimate is 1.7-fold (0.24 log units) above it, within the range that was stated.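

In this assay, placing 2,3-dichlorophenyl for 4-hydroxyphenyl on the core of compound 3 gives a 1.2-fold lower number from compound 3 to compound 4 (0.08 log units; within the scatter), so on this core the two groups are not told apart. The same change on the other core cannot be read, as compound 1 and compound 2 both stand at a limit of the assay: the limit of > 20000 nM in this assay, at which 2 of the 4 values shown sit. The change is therefore read on one core only, which shows no step beyond the scatter there and does not show whether that result carries over to the core of compound 1.

Still open, as far as these compounds go, is whether a phenyl ring carrying an amine or a carboxylic acid at this place would give a clearly different number on either core. Also open, from the compounds shown here alone, is whether any group at this place brings the core of compound 1 into the range reported as a number.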